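The source may hold more compounds than are shown below. What is called first, only, known or untested is meant among the compounds shown, and "the series" means these compounds.

Going by the values given here, in an ADME assay on HepG2 cells (Homo sapiens) for cytotoxicity, read by MTT assay, with a stated time of 24 h (on this read-out higher numbers stand for lower toxicity in this test and lower numbers for higher toxicity in this test), compound 1 `Cc1ccc(-c2cn(-c3ccnc4cc(Cl)ccc34)nn2)cc1` gives 352000 nM as the only actual number in the set. Compound 2 `COc1ccc2cc(-c3cn(-c4ccnc5cc(Cl)ccc45)nn3)ccc2c1` returns > 2590000 nM as a limit and not a number. Compound 3 `Cc1ccc(C(=O)OCCCc2cn(-c3ccnc4cc(Cl)ccc34)nn2)cc1` likewise returns > 2460000 nM as a limit and not a number. Compound 4 `Clc1ccc2c(-n3cc(CN4CCCCC4)nn3)ccnc2c1` has not yet been measured. It keeps the core of compound 1 but carries (piperidin-1-yl)methyl in place of 4-methylphenyl on an aromatic carbon on an aromatic carbon of the five-membered aromatic ring with 3 nitrogen. Among the compounds with values here, no measured step between two compounds is available to size such a change. Within the data shown here, the only numerical anchor is compound 1 at 352000 nM in this assay for this expectation. The expected change is a modest one toward lower toxicity, a 1.4-fold higher number from compound 1 to compound 4 (0.15 log units; within the scatter) as estimated, though the direction remains uncertain. Compound 4 is estimated at 500000 nM in this assay with an expected range from 120000 nM to 2000000 nM for a single measurement.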

Compound 4, half-maximal cytotoxic concentration: 1110000 nM
Beside the measured number, compound 4's estimate is 2.2-fold (0.35 log units) below it; the range from low to high includes it.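

In this assay, going by these compounds alone, placing (piperidin-1-yl)methyl in place of 4-methylphenyl on an aromatic carbon of the five-membered aromatic ring with 3 nitrogen gives the only sized step at this position: a 3.2-fold higher number from compound 1 to compound 4 (0.50 log units; beyond the scatter). The change moves the read-out toward lower toxicity in this test, and it replaces a six-membered aromatic ring of carbon only with a six-membered non-aromatic ring with 1 hetero atom, with no change in the number of heavy atoms. No measurement shown accounts for this step.

The compounds shown leave open whether the step follows the ring nitrogen or the loss of the aromatic ring, which a cyclohexylmethyl or a morpholin-4-ylmethyl group at the same carbon would help to separate. As far as these compounds go, how an open-chain amine or a carboxylic acid at this carbon would read in this assay also remains open.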